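The compounds below may be only part of what the source reports. "The series", "measured", "known", "first", "only" and "open" are said of these compounds alone.

In a functional assay (aorta) with Oryctolagus cuniculus as the target (a lower number here means tighter binding, a higher number weaker binding), three compounds sharing one core have been measured. Compound 1 `COc1cc(C(=O)O)ccc1OCCCN1CCC(C(c2ccc(F)cc2)c2ccc(F)cc2)CC1`, which carries a carboxy group, gives 79.4 nM. Compound 2 `COc1cc(C#N)ccc1OCCCN1CCC(C(c2ccc(F)cc2)c2ccc(F)cc2)CC1`, with cyano in place of carboxy, gives 2 nM, and the step is large: a 40-fold lower number from compound 1 to compound 2 (1.60 log units; beyond the scatter). Compound 3 `Fc1ccc(C(c2ccc(F)cc2)C2CCN(CCCOc3ccc(Br)cc3)CC2)cc1` gives 1.59 nM. Its gap to the nearest measured compound is small: a 1.3-fold lower number from compound 2 to compound 3 (0.10 log units; within the scatter). Its gap to the furthest is large: a 50-fold lower number from compound 1 to compound 3 (1.70 log units; beyond the scatter).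

The next compound, compound 4 `COc1ccccc1OCCCN1CCC(C(c2ccc(F)cc2)c2ccc(F)cc2)CC1`, has 2-methoxyphenyl in place of 4-bromophenyl on an oxygen on a saturated carbon. Within the data shown here, no measured step makes this exact change. The closest evidence is the exchange of 4-cyano-2-methoxyphenyl for 4-bromophenyl, which stayed within the scatter: a 1.3-fold lower number from compound 2 to compound 3 (0.10 log units; within the scatter). Both large steps start from compound 1, and compound 4 has no carboxy group, so they offer little guidance here. Compound 4 does, however, lack both the cyano group of compound 2 and the bromine of compound 3, and the data do not show what losing either would do. Only a small move toward a higher number is therefore expected, not beyond the scatter: a 1.9-fold higher number from compound 3 to compound 4 (0.28 log units; within the scatter). Compound 4 is estimated at 3 nM, with an expected range from 1 nM to 10 nM.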

Compound 4, dissociation constant: 2.51 nM
Beside the measured number, compound 4's estimate is 1.2-fold (0.08 log units) above it; measured number inside the range.
By their numbers in this assay, from the lowest: compounds 3, 2 and 4 (each within the scatter of the next); then compound 1.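

In this assay, 2-methoxyphenyl in place of 4-bromophenyl on the oxygen on a saturated carbon stays within the scatter (a 1.6-fold higher number from compound 3 to compound 4 (0.20 log units; within the scatter)), so these two quite different aryl groups read alike here on the shared core. The new compound also gives the first direct view of the cyano group alone: with hydrogen in place of cyano on the aromatic carbon, the change again stays within the scatter (a 1.3-fold higher number from compound 2 to compound 4 (0.10 log units; within the scatter)), so the cyano group of compound 2 is not needed for a number of this size. Hydrogen in place of carboxy on that same carbon, by contrast, is a large step (a 32-fold lower number from compound 1 to compound 4 (1.50 log units; beyond the scatter)), so among hydrogen, cyano and carboxy at this place only carboxy stands apart.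

Nothing shown here gives a measured reason why the carboxy compound stands apart. Going by these compounds, it remains open whether an amine, a primary amide or a methyl ester on that aromatic carbon would read like hydrogen and cyano or like carboxy, and whether a longer chain between the oxygen and the core would leave these numbers as they are.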